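Dithiocarbamate triazoles: from a tolyl to a dichlorobenzyl arm

The source may report more compounds than this note shows. Statements on the series, on what has been measured and on what is new or still open speak of the compounds shown alone.

Among the measured compounds shown here, the three compounds measured so far share a piperazine dithiocarbamate core linked through a methylene to a triazole. Compound 1 `COc1cc(Cn2cc(CSC(=S)N3CCNCC3)nn2)cc(OC)c1OC` carries a trimethoxybenzyl group on the ring nitrogen and a free amine on the piperazine; in a functional assay on PC-3 cells (Homo sapiens) for inhibition, read by MTT assay, with a stated time of 72 h (a higher number here means a weaker inhibitor, a lower number a stronger inhibitor), compound 1 gives only a limit, > 128000 nM. Compound 3 `COc1cc(Cn2cc(CSC(=S)N3CCN(C(=O)OCc4ccccc4)CC3)nn2)cc(OC)c1OC` differs by a benzyloxycarbonyl in place of hydrogen on an amine nitrogen in a ring, and in this assay compound 3 likewise gives a limit, > 128000 nM. The step that the two limits leave unreadable from compound 1 to compound 3 is therefore not readable. Compound 2 `Cc1ccc(-n2cc(CSC(=S)N3CCN(C(=O)OC(C)(C)C)CC3)nn2)cc1` bears a tert-butoxycarbonyl on the piperazine and a 4-methylphenyl on the aromatic nitrogen; in this assay compound 2 also gives a limit, > 128000 nM, so it stands with the others at the limit of > 128000 nM in this assay, at which 3 of the 3 values shown sit.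

Compound 4 `CC(C)(C)OC(=O)N1CCN(C(=S)SCc2cn(Cc3ccc(Cl)c(Cl)c3)nn2)CC1` keeps the tert-butoxycarbonyl piperazine dithiocarbamate of compound 2 and changes only the group on the aromatic nitrogen: 3,4-dichlorobenzyl in place of 4-methylphenyl on an aromatic nitrogen. For the measured compounds named here, no measured step reports a readable effect of any change at that position, and every recorded value sits at the limit. The step from compound 2 to compound 4 is therefore expected to be small, a step that the limit leaves unreadable from compound 2 to compound 4, with an expected result again at or near the limit. Compound 4 is estimated at 150000 nM, within 40000 nM to 600000 nM.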

Compound 4, half-maximal inhibitory concentration: > 128000 nM
Compound 4: a limit, no number; the forecaster's own chance of this, stated with the estimate: 75%; the middle value is on the limit's open side.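

In this assay compound 4 gives > 128000 nM, which is a limit and not a number. Compound 2 also gives only a limit, so the step between compound 2 and compound 4 cannot be read. The compounds shown leave open what any of their structural changes does to inhibition in this assay, and all share one limit: the limit of > 128000 nM in this assay, at which 4 of the 4 values shown sit.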